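Cyclooctyl for cyclopropyl on the amide nitrogen: tolerance

The compounds below may be only part of what the source reports. "The series", "measured", "known", "first", "only" and "open" are said of these compounds alone.

Measured so far:
compound 1, `CC(=O)N(CCCCCCN1C[C@H](O)[C@@H](O)[C@H](O)[C@H]1CO)C1CCCCC1`, > 500000 nM
compound 2, `CC(C)(C)C(=O)N(CCCCCCN1C[C@H](O)[C@@H](O)[C@H](O)[C@H]1CO)C1CC1`, "not determined" (no result reported)

Compound 1 gives in an ADME assay on Huh-7 cells (Homo sapiens) for cytotoxicity, read by MTT assay (a lower number here means that less compound is tolerated, a higher number that more compound is tolerated), only a limit of the assay, > 500000 nM. For compound 2 the result in this assay is "not determined" (no result reported), so compound 2 stands on no number at all; the only figure in the series is the limit of > 500000 nM in this assay, at which 1 of the 2 values shown sits. Within the data shown here, no step between two measured compounds exists, and no pair differing in one place has been run.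

Compound 3, `CC(C)(C)C(=O)N(CCCCCCN1C[C@H](O)[C@@H](O)[C@H](O)[C@H]1CO)C1CCCCCCC1`, carries cyclooctyl in place of cyclopropyl on an amide-type nitrogen. Nothing measured tells the size of this step. The expectation is that the step from compound 2 to compound 3 in this assay is small, toward a lower number if anything, and with a fair chance that compound 3 again reaches only the limit. Compound 3 is estimated at 300000 nM in this assay, within 100000 nM to 500000 nM.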

Compound 3, half-maximal cytotoxic concentration: 150000 nM
Compound 3: the middle estimate sits 2.0-fold (0.30 log units) above what was measured, and the stated range covers the measured number.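

In this assay, among these compounds, compound 2 gives "not determined" (no result reported) and compound 3 gives 150000 nM, so no step between them can be read, and compound 1 differs from compound 3 in more than one place. The compounds shown leave open how tolerance changes with ring size on the amide-type nitrogen.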